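Adding a cyclopropyl ring at the aromatic nitrogen

This account rests on a few compounds, and the source may have more. Where it says the series, first, only, none or still open, it means among the compounds named here.

- compound 1 `COc1cc(C(=O)N2CCC(O)CC2)cc2nc(NCc3cccc(Cl)c3)oc12` gives 21.7 mL/min/kg
- compound 2 `COc1cc(C(=O)N2CCC(O)C(C)C2)cc2nc(NCc3cccc(Cl)c3)oc12` gives 45 mL/min/kg
- compound 3 `COc1cc(C(=O)N2CC[C@@H](O)[C@H](C)C2)cc2nc(NCc3cccc(Cl)c3)oc12` gives 38.3 mL/min/kg

These values come from an ADME assay on cells (Hepatocyte, Rattus norvegicus, strain Wistar) for pharmacokinetics, read by LC-MS, with a stated time of 90 min, tested at 1 uM; a higher number here means faster removal of the compound, a lower number slower removal. Compound 2 stands at the upper end of the set, level with compound 3 in a 1.2-fold lower number from compound 2 to compound 3 (0.07 log units; within the scatter) and clear of compound 1 in a 2.1-fold higher number from compound 1 to compound 2 (0.32 log units; beyond the scatter).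

Compound 4 `COc1cc(C(=O)N2CCC(O)C(C)C2)cc2nc(NC3(c4cccc(Cl)c4)CC3)oc12` carries 1-(3-chlorophenyl)cyclopropyl in place of 3-chlorobenzyl on a nitrogen on an aromatic ring.

Going by the values given here, no measured step changes that place. The nearest guides are the methyl additions on a saturated ring carbon, a 2.1-fold higher number from compound 1 to compound 2 (0.32 log units; beyond the scatter) and a 1.8-fold higher number from compound 1 to compound 3 (0.25 log units; within the scatter), and both are small. No clear shift in either direction is therefore expected, only a 1.1-fold lower number from compound 2 to compound 4 (0.03 log units; within the scatter). Compound 4 is estimated at 42 mL/min/kg with an expected range from 20 mL/min/kg to 80 mL/min/kg.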

Compound 4, clearance: 46.7 mL/min/kg
The estimate for compound 4 lay 1.1-fold (0.05 log units) below the measured number, and the stated range covers the measured number.
By their numbers in this assay, from the lowest: compounds 1, 3, 2 and 4 (each within the scatter of the next, the first and the last beyond it).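

The swap of 3-chlorobenzyl for 1-(3-chlorophenyl)cyclopropyl on the nitrogen gives a 1.0-fold higher number from compound 2 to compound 4 (0.02 log units; within the scatter) in this assay, so this first change away from the saturated ring leaves clearance level. At this position in this series, the added three-membered ring is tolerated without a shift in removal rate beyond the scatter. Nothing available explains why the number holds steady.

Still open, on these data alone, is whether the same swap would hold on the unmethylated ring of compound 1, and whether a larger 1-(3-chlorophenyl)cyclobutyl group or a benzyl carrying an amine would behave alike.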